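Moving the chlorine once more around the phenylpiperazine

The compounds below may be only part of what the source reports. "The series", "measured", "known", "first", "only" and "open" are said of these compounds alone.

The series consists of phenylpropyl-piperazines that differ only in the chlorophenyl group attached to the ring nitrogen. Compound 1 `Clc1ccccc1N1CCN(CCCc2ccccc2)CC1` gives 0.56 nM in an assay on brain for displacement of a labelled ligand from Sigma non-opioid intracellular receptor 1 (Rattus norvegicus), read by scintillation counting, with a stated time of 120 min (on this read-out higher numbers stand for weaker inhibition and lower numbers for stronger inhibition), and compound 2 `Clc1cccc(N2CCN(CCCc3ccccc3)CC2)c1` gives 4.93 nM in this assay. For the measured compounds named here, of the two numbers measured so far, compound 2 therefore stands highest, and the single step of an 8.8-fold higher number from compound 1 to compound 2 (0.94 log units; beyond the scatter) shows how far the two lie apart. Compound 3 `Clc1ccc(N2CCN(CCCc3ccccc3)CC2)cc1` is yet to be measured, and it differs from compound 2 by 4-chlorophenyl in place of 3-chlorophenyl on an amine nitrogen in a ring. Going by the values given here, the only step that bears on this change is the one from compound 1 to compound 2, which moved the chlorine one position around the same ring and weakened binding by a modest amount. Among the compounds with values here, a second move of the chlorine has no measured counterpart, so its direction cannot be read from the data; a step of the same order in either direction, or none beyond the scatter, is plausible. Compound 3 is therefore expected to give 6 nM, within a range of 1.5 nM to 25 nM, which corresponds to an expected step of a 1.2-fold higher number from compound 2 to compound 3 (0.09 log units; within the scatter).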

Compound 3, inhibition constant: 0.12 nM
Estimate against measurement, compound 3: 50-fold (1.70 log units) above; measured number below the stated range.
By their numbers in this assay, from the lowest: compound 3; then compound 1; then compound 2.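

The chlorine position does not act in one direction: the 4-chlorophenyl group reverses the loss seen with the 3-chlorophenyl group and goes well past it, with a 41-fold lower number from compound 2 to compound 3 (1.61 log units; beyond the scatter) in this assay, a large step where the earlier change of position had been a modest one. The 2-chlorophenyl compound, already a low number in this small set, is also surpassed, with a 4.7-fold lower number from compound 1 to compound 3 (0.67 log units; beyond the scatter), so that compound 3 has the lowest number of the three, its steps to both others lying beyond the scatter, and the 3-chlorophenyl group is the one position of the three that stands apart on the weak side. The compounds shown offer no measured information that would account for this order of the three positions.

From the compounds shown here alone, whether the advantage belongs to chlorine itself or to any group at that place stays open, since a plain phenyl, a 4-fluorophenyl or a 4-methoxyphenyl group would be needed to tell these apart. Going by these compounds, it is equally open whether the same order of positions would hold with a shorter or longer chain in place of the phenylpropyl group on the other ring nitrogen.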